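This account rests on a few compounds, and the source may have more. Where it says the series, first, only, none or still open, it means among the compounds named here.

Compound 1 `CC(C)=CCC1Cc2c(OCc3ccccc3)cc(=O)n(CCCO)c2CC1(C)C`: -0.3%
Compound 2 `CC(C)=CCC/C(C)=C/COc1cc(=O)n(CCCO)c2c1CC(CC=C(C)C)C(C)(C)C2`: 10.6%
Compound 3 `CC(C)=CCC1Cc2c(OCCCNC(=O)c3ccco3)cc(=O)n(CCCO)c2CC1(C)C`: 2.1%

In a functional assay on PANC-1 cells (Homo sapiens) for inhibition, read by MTT assay, with a stated time of 24 h, tested at 10 uM (a lower number here means less inhibition, a higher number more inhibition at the concentration tested (going by the name of the read-out)), compound 1 gives -0.3%, the lowest of the three numbers. Compound 3 sits nearest, the step of a number 2.4 percentage points higher from compound 1 to compound 3 (within the scatter) lying within the scatter; compound 2 is furthest, the step of a number 10.9 percentage points higher from compound 1 to compound 2 (beyond the scatter) being the only one in the set that clears the scatter, and even that one is modest.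

Compound 4 `CC(C)=CCC/C(C)=C/CC1Cc2c(OCc3ccccc3)cc(=O)n(CCCO)c2CC1(C)C` differs from compound 1 by 3-methylbut-2-en-1-yl in place of hydrogen on a saturated chain carbon bound to a double-bonded chain carbon. Going by the values given here, no measured step touches this place: the three measured compounds all vary the group on the saturated chain carbon bound to the oxygen on the aromatic ring, while the chain on the core stays fixed. The closest analogy is the step of a number 10.9 percentage points higher from compound 1 to compound 2 (beyond the scatter), in which a longer dienyl chain entered at a different place and the number rose modestly. Whether a chain extension on the core behaves alike is not known from these data. The expectation is therefore a step of a number 3.3 percentage points higher from compound 1 to compound 4 (within the scatter), that is, no change beyond the scatter, with a small rise as the more likely side. Compound 4 is estimated at 3%, with a range from -8% to 14%.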

Compound 4, a percentage reported as inhibition, at one concentration (the size of the read-out at that concentration, not a potency): 46.5%
For compound 4 the middle estimate is 43.5 percentage points below the measured one; the whole stated range lies below it.
By their numbers in this assay, from the lowest: compounds 1, 3 and 2 (each within the scatter of the next, the first and the last beyond it); then compound 4.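

In this assay, going by these compounds alone, the chain on the core turns out to be a responsive place, which the earlier compounds, all sharing that chain, could not show: a number 46.8 percentage points higher from compound 1 to compound 4 (beyond the scatter) follows when 3-methylbut-2-en-1-yl replaces hydrogen on a saturated chain carbon bound to a double-bonded chain carbon, so that 3-methylbut-2-en-1-yl becomes 3,7-dimethylocta-2,6-dien-1-yl. This large step compares with the modest a number 10.9 percentage points higher from compound 1 to compound 2 (beyond the scatter) for a change on a saturated chain carbon bound to an oxygen on an aromatic ring, so in these compounds the size of the step depends on the place changed. Nothing at hand explains the rise.

Going by these compounds, it remains open whether a longer chain, a fully saturated chain of the same length or a terminal amine would hold this level. Also open, on these data alone, is whether the 3,7-dimethylocta-2,6-dien-1-yl chain gives a similar step when the benzyl group on the oxygen is replaced.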